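The source may report more compounds than this note shows. Statements on the series, on what has been measured and on what is new or still open speak of the compounds shown alone.

Measured so far:
- compound 1, `N#Cc1c(N)nc2sc(C(N)=O)c(N)c2c1-c1ccc(OCC2CC2)cc1`, 19%
- compound 2, `N#Cc1c(N)nc(SCC(=O)NCO)c(C#N)c1-c1ccc(OCC2CC2)cc1`, 10%
- compound 3, `CC(=O)Nc1ccc(-c2c(C#N)c(N)nc(SCC(N)=O)c2C#N)cc1`, 17%

All three compounds were tested in an assay on CHO cells for displacement of a labelled ligand from adenosine receptor A1 (Homo sapiens), read by scintillation counting, with a stated time of 90 min, tested at 1 uM; on this read-out lower numbers stand for less inhibition and higher numbers for more inhibition at the one concentration tested (going by the name of the read-out). In this assay compound 1 gives 19%, compound 3 gives 17%, and compound 2 gives 10%. The number for compound 2 is the smallest of the three on paper, but its gap to compound 3 and its gap to compound 1 both fall within the usual scatter of repeated measurements, so the three compounds cannot be separated from one another on these data. Among the compounds with values here, no two of the measured compounds differ in a single place, so no step has been computed between them.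

Compound 4, `CNC(=O)CSc1nc(N)c(C#N)c(-c2ccc(OCC3CC3)cc2)c1C#N`, has not yet been measured. It is derived from compound 2 by a single change: hydrogen in place of hydroxy on a saturated chain carbon bound to an amide-type nitrogen. Put another way, the hydroxymethyl group on the amide-type nitrogen becomes a methyl group. Since the three measured compounds all sit low in this assay and lie within scatter of one another, no step beyond the scatter is expected from compound 2 to compound 4 in either direction; the expected step is a number 3 percentage points higher from compound 2 to compound 4 (within the scatter). Compound 4 is therefore estimated at 13%, with a range from 0% to 30%.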

Compound 4, a percentage reported as inhibition, at one concentration (the size of the read-out at that concentration, not a potency): 14%
Compound 4: the middle estimate sits 1 percentage points below what was measured; low and high end bracket the measured number.
By their numbers in this assay, from the lowest: compounds 2, 4, 3 and 1 (each within the scatter of the next).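

In this assay, within the data shown here, hydrogen in place of hydroxy on a saturated chain carbon bound to an amide-type nitrogen gives a number 4 percentage points higher from compound 2 to compound 4 (within the scatter), and this is the only pair of measured compounds that differ in one place. At this position, then, the read-out does not separate hydroxymethyl from methyl: in this one pair, the hydroxy group, with its one hydrogen-bond donor and one hydrogen-bond acceptor, can be removed without a step beyond the scatter, a reading that cannot be extended to other positions or to other cores. Nothing in the available data offers an explanation for the size of this step.

The compounds shown leave open whether a longer chain such as propyl on the amide-type nitrogen, or a carboxylic acid in place of the whole amide, would give a step beyond the scatter from compound 4. They also leave open whether hydrogen in place of hydroxy at this kind of place would read the same on the core of compound 1.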